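Permeability notes on a diamine series

The source may report more compounds than this note shows. Statements on the series, on what has been measured and on what is new or still open speak of the compounds shown alone.

Measured so far:
compound 1 `COc1cccc(CNCCCNc2ccnc3cc(Cc4ccccc4)ccc23)c1O` — 23 10^-6 cm/s
compound 2 `COc1ccc(F)cc1CNCCCNc1ccnc2cc(Cc3ccccc3)ccc12` — 23 10^-6 cm/s
compound 3 `c1ccc(Cc2ccc3c(NCCCNCc4ccco4)ccnc3c2)cc1` — 23 10^-6 cm/s

Three compounds have been run in an ADME assay for permeability, using PAMPA, with a stated time of 30 min, at pH 7.4; a lower number here means that the compound crosses the layer more slowly, a higher number that the compound crosses the layer faster. Compound 1 gives 23 10^-6 cm/s, compound 2 gives 23 10^-6 cm/s and compound 3 gives 23 10^-6 cm/s; compound 1 therefore stands level with compounds 2 and 3 at the digits shown. The measured steps all vary the group on a saturated chain carbon bound to an amine nitrogen: no change at the digits printed from compound 1 to compound 2 (within the scatter), no change at the digits printed from compound 1 to compound 3 (within the scatter) and no change at the digits printed from compound 2 to compound 3 (within the scatter). None of them moved the read-out beyond the scatter.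

Compound 4 `COc1ccccc1Oc1ccc2c(NCCCNCc3cccc(OC)c3O)ccnc2c1` is next for this assay. Relative to compound 1 the change is 2-methoxyphenoxy in place of benzyl on an aromatic carbon. This is a different place from the one varied in the measured steps, so none of those steps bears directly on it; the three measured values only show that the shared core has so far returned the same read-out whatever the group on the saturated chain carbon. On that basis a step of no more than the usual scatter is expected, a 1.3-fold lower number from compound 1 to compound 4 (0.11 log units; within the scatter), with no direction claimed. Compound 4 is estimated at 18 10^-6 cm/s, within a range of 9 10^-6 cm/s to 36 10^-6 cm/s.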

Compound 4, apparent permeability: 317 10^-6 cm/s
Beside the measured number, compound 4's estimate is 18-fold (1.25 log units) below it, and the stated range ends below it.
By their numbers in this assay, from the lowest: compounds 1, 2 and 3 (each within the scatter of the next); then compound 4.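

In this assay the aromatic carbon proves to be a sensitive place in the series: with the rest of compound 1 unchanged, 2-methoxyphenoxy in place of benzyl gives a 14-fold higher number from compound 1 to compound 4 (1.14 log units; beyond the scatter) on this one substitution. The level read-out shared by compound 1, compound 2 and compound 3 therefore describes only changes on the saturated chain carbon and does not extend to the series as a whole, as a single change elsewhere in the molecule lies well beyond the scatter. The entering group differs from benzyl in carrying oxygen and hydrogen-bond acceptors, but no measurement at hand accounts for the step.

This single step changes the link to the ring and adds the methoxy group at the same time, so the compounds shown cannot say which of the two carries it, and a plain phenoxy group would be needed to separate them. Also open, going by these compounds, is whether the step holds with furan-2-yl or 5-fluoro-2-methoxyphenyl on the saturated chain carbon, and how an amine or a carboxylic acid on the same aromatic carbon would read.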